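A few compounds are considered here, and "the series" means these few. Any claim that something is new, unique, unknown or untested is made for them only; others in the source may bear on it.

Among the compounds with values here, compound 1 `CCCC(=O)Nc1cccc(NC(=O)c2ccccc2C)c1` gives 770 nM in an assay on a cell-free system (plasma) for inhibition of proteinase-activated receptor 1 (Homo sapiens), read by flow cytometry, with a stated time of 20 min (a higher number here means a weaker inhibitor, a lower number a stronger inhibitor), the highest of the two numbers measured so far. Within the data shown here, its only neighbour is compound 2 `CCCC(=O)Nc1cccc(NC(=O)c2ccccc2OC(F)(F)F)c1`, which gives 710 nM in this assay, the step being a 1.1-fold lower number from compound 1 to compound 2 (0.04 log units; within the scatter). Compound 3 `CCCC(=O)Nc1cccc(NC(=O)c2c(C)cccc2C)c1` differs from compound 1 by methyl in place of hydrogen on an aromatic carbon. Among the measured compounds shown here, no measured step covers a methyl entering for hydrogen on this ring; the change from compound 1 to compound 2, small as it was, is the only step and touches a different group. Hence no move beyond the scatter is expected for compound 3, an estimated 1.0-fold lower number from compound 1 to compound 3 (0.01 log units; within the scatter), giving about 750 nM with a range of 350 nM to 1600 nM.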

Compound 3, half-maximal inhibitory concentration: 3000 nM
Beside the measured number, compound 3's estimate is 4.0-fold (0.60 log units) below it; measured number outside the range, above it.
By their numbers in this assay, from the lowest: compounds 2 and 1 (each within the scatter of the next); then compound 3.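

In this assay, methyl in place of hydrogen on this aromatic carbon, ortho to a large group and meta to a methyl group, gives a 3.9-fold higher number from compound 1 to compound 3 (0.59 log units; beyond the scatter). Within the data shown here, this is the only step so far that lies beyond the scatter, so this position responds to a single added methyl, whereas a 1.1-fold lower number from compound 1 to compound 2 (0.04 log units; within the scatter) showed no such move. No measurement shown accounts for this step.

Open, on these data alone, is whether an amine or a hydroxyl group on this same carbon gives a similar step. Also open, as far as these compounds go, is whether the added methyl has the same effect when trifluoromethoxy replaces the existing methyl.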